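The compounds below may be only part of what the source reports. "The series", "measured", "known", "first", "only" and "open" are said of these compounds alone.

Measured compounds:
compound 1 `COc1ccc2nc(C)cc(OCC(=O)Nc3cc(C)cc(C)c3)c2c1` — 1.3 mL.min-1.g-1
compound 2 `Cc1cc(C)cc(NC(=O)COc2cc(C)nc3ccc(C)cc23)c1` — 1.6 mL.min-1.g-1
compound 3 `COc1ccc2nc(C)cc(OC(C)(C)C(=O)Nc3cc(C)cc(C)c3)c2c1` — 2.7 mL.min-1.g-1

In an ADME assay on microsomes from liver (Homo sapiens) for metabolic stability, read by LC-MS, using NADPH, with a stated time of 30 min, tested at 0.5 uM (a higher number here means faster removal of the compound, a lower number slower removal), compound 1 has the lowest number of the three measured compounds. For the measured compounds named here, compound 2 sits nearest to it, and the only single-point step among the measured compounds, a 1.2-fold higher number from compound 1 to compound 2 (0.09 log units; within the scatter), lies within the scatter. Compound 3 gives the highest of the three numbers, and its gap to compound 1 is beyond the scatter; the two differ at the linker rather than at the aromatic ring, so this pair is not a direct guide to the change considered here.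

Compound 4 `COc1ccc2nc(C)cc(OCC(=O)Nc3cccc(C)c3)c2c1` differs from compound 1 by hydrogen in place of methyl on an aromatic carbon, that is, 3,5-dimethylphenyl becomes 3-methylphenyl. Going by the values given here, no measured step touches the methyl groups on this ring, so the only step that bears on it, from compound 1 to compound 2, suggests that a small change on an aromatic ring need not move the number beyond the scatter. Compound 4 is therefore expected to show a 1.2-fold lower number from compound 1 to compound 4 (0.07 log units; within the scatter), a step of no clear direction. The value of compound 4 in this assay is estimated at 1.1 mL.min-1.g-1, between 0.5 mL.min-1.g-1 and 2.5 mL.min-1.g-1.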

Compound 4, intrinsic clearance in microsomes: 2.5 mL.min-1.g-1
The estimate for compound 4 lay 2.3-fold (0.36 log units) below the measured number; the measured number falls inside the stated range.
By their numbers in this assay, from the lowest: compounds 1, 2, 4 and 3 (each within the scatter of the next, the first and the last beyond it).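

For the compounds shown here, the compounds give a first reading at the 3,5-dimethylphenyl ring: in this assay, the change to 3-methylphenyl gives a 1.9-fold higher number from compound 1 to compound 4 (0.28 log units; within the scatter). One of the two methyl groups on this ring can thus be replaced by hydrogen without the number leaving the scatter, and the same holds for the methoxy-to-methyl change elsewhere in the molecule, a 1.2-fold higher number from compound 1 to compound 2 (0.09 log units; within the scatter). Nothing available accounts for the size of the step at this position.

From the compounds shown here alone, it remains open whether a plain phenyl ring, with both methyl groups gone, would stay within the scatter of compound 1. Also open, going by these compounds, is whether a chlorine, a methoxy group or an amine on this aromatic carbon would do so, and whether the step would hold with the linker of compound 3.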